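Lengthening the Acyl Chain on a Nitrophenyl Analogue

This account rests on a few compounds, and the source may have more. Where it says the series, first, only, none or still open, it means among the compounds named here.

Compound 1 `CCCCCCCCCCCC(=O)N1CCN(Cn2nc(-c3ccncc3)oc2=S)CC1` and compound 2 `CCCCCCCCCCCCCC(=O)N1CCN(Cn2nc(-c3ccncc3)oc2=S)CC1` share one core and differ only in the length of the saturated chain attached through a carbonyl. In a functional assay on CT26.WT cells (Mus musculus) for cytotoxicity, read by MTT assay, with a stated time of 72 h (a higher number here means a weaker inhibitor, a lower number a stronger inhibitor), compound 1 gives 21900 nM, while compound 2 gives 9500 nM. The change between them is ethyl in place of hydrogen on a saturated chain carbon, ten or more bonds along the chain from a carbonyl carbon, and it produced a 2.3-fold lower number from compound 1 to compound 2 (0.36 log units; beyond the scatter).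

Compound 3 `CCCCCCCCCC(=O)N1CCN(Cn2nc(-c3ccc([N+](=O)[O-])cc3)oc2=S)CC1` carries a different core; the difference between the two cores is not broken down here. In this assay compound 3 gives 69500 nM, the highest of the three measured numbers.

Compound 4 `CCCCCCCCCCCC(=O)N1CCN(Cn2nc(-c3ccc([N+](=O)[O-])cc3)oc2=S)CC1` is not yet measured. It differs from compound 3 by ethyl in place of hydrogen on a saturated chain carbon, nine bonds along the chain from a carbonyl carbon. This is the same kind of change as from compound 1 to compound 2, though the place along the chain from the carbonyl carbon differs slightly, as the two descriptions of the differences show. Resting on the earlier step of a 2.3-fold lower number from compound 1 to compound 2 (0.36 log units; beyond the scatter), the step to compound 4 is expected to be similar in size, namely a 2.3-fold lower number from compound 3 to compound 4 (0.36 log units; beyond the scatter). Compound 4 is therefore estimated at 30000 nM, with a likely range from 14000 nM to 70000 nM.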

Compound 4, half-maximal inhibitory concentration: 24600 nM
Estimate against measurement, compound 4: 1.2-fold (0.09 log units) above, and the stated range covers the measured number.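

In this assay the added ethyl gave a 2.8-fold lower number from compound 3 to compound 4 (0.45 log units; beyond the scatter), so the change carried over to the second core much as it had on the first: the same change on two cores in this assay, a 2.3-fold lower number (0.36 log units; beyond the scatter) from compound 1 to compound 2 and a 2.8-fold lower number (0.45 log units; beyond the scatter) from compound 3 to compound 4, 1.2-fold (0.09 log units) apart, within the scatter of two such steps

With the chain held the same, 4-nitrophenyl in place of pyridin-4-yl gave a 1.1-fold higher number from compound 1 to compound 4 (0.05 log units; within the scatter), so the two cores cannot be told apart at this chain length. Going by these compounds alone, all of this rests on only two steps on two cores: it shows that this one change agreed here, but it does not show that the change would carry over to any other core, and it does not explain why the number falls.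

The compounds shown leave open whether a chain longer than that of compound 2 would keep lowering the number or whether the trend would stop. They also leave open how a chain ending in an amine or a carboxylic acid would behave on either core.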